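Two difluorophenyl isomers on a thiophene core

This account rests on a few compounds, and the source may have more. Where it says the series, first, only, none or still open, it means among the compounds named here.

compound 1 `CC(C)(C)Cc1c(-c2ccoc2)sc(N)c1C(=O)c1ccc(Cl)cc1` in an assay on CHO cells for displacement of a labelled ligand from adenosine receptor A1 (Homo sapiens), read by scintillation counting, tested at 10 uM; on this read-out higher numbers stand for more inhibition at the one concentration tested (going by the name of the read-out) and lower numbers for less inhibition: 1%
compound 2 `CC(C)(C)Cc1c(-c2cccc(F)c2F)sc(N)c1C(=O)c1ccc(Cl)cc1` in this assay: 1%

Compound 2 stands level with compound 1 at the digits shown. Compound 3 `CC(C)(C)Cc1c(-c2cc(F)ccc2F)sc(N)c1C(=O)c1ccc(Cl)cc1` differs from compound 2 only in 2,5-difluorophenyl in place of 2,3-difluorophenyl on an aromatic carbon. For the measured compounds named here, the one measured step that bears on this place is no change at the digits printed from compound 1 to compound 2 (within the scatter), a change of the same aromatic group that left the read-out where it was. A difluorophenyl already sits there in compound 2, so compound 3 is expected to show a number 1 percentage points higher from compound 2 to compound 3 (within the scatter). For compound 3 the estimate is 2%, between -5% and 12%.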

Compound 3, a percentage reported as inhibition, at one concentration (the size of the read-out at that concentration, not a potency): 3%
For compound 3 the middle estimate is 1 percentage points below the measured one, within the range that was stated.
By their numbers in this assay, from the lowest: compounds 1, 2 and 3 (each within the scatter of the next).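

In this assay, shifting a fluorine, with 2,5-difluorophenyl in place of 2,3-difluorophenyl, gives a number 2 percentage points higher from compound 2 to compound 3 (within the scatter) and so this isomer swap leaves the read-out within the scatter. The replacement of furan-3-yl by 2,5-difluorophenyl gives a number 2 percentage points higher from compound 1 to compound 3 (within the scatter) and so all three aromatic groups at this place read alike. No available evidence accounts for this flat reading. From the compounds shown here alone, whether any group here can raise the inhibition stays open, for example a phenyl ring carrying an amine or a carboxylic acid, or a longer chain in place of the ring. The compounds shown also leave open whether changing the neopentyl group would alter the read-out.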